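The source may hold more compounds than are shown below. What is called first, only, known or untested is meant among the compounds shown, and "the series" means these compounds.

Compound 1 `CCCCCC1(OC)CCN(c2ccc(C(=O)NS(=O)(=O)c3ccc(N[C@H](CCN(C)C)CSc4ccccc4)c([N+](=O)[O-])c3)cc2)CC1`: 20 nM
Compound 2 `CN(C)CC[C@H](CSc1ccccc1)Nc1ccc(S(=O)(=O)NC(=O)c2ccc(N3CCC(=Cc4ccc(F)cc4)CC3)cc2)cc1[N+](=O)[O-]`: 3.4 nM

Both numbers come from an assay on isolated protein for displacement of a labelled ligand from Apoptosis regulator Bcl-2 (Homo sapiens), read by fluorescence polarization; on this read-out lower numbers stand for stronger inhibition and higher numbers for weaker inhibition. Of the two, compound 2 stands lowest, and the gap to compound 1 lies beyond the usual scatter, so compound 2 is the stronger binder here.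

Compound 3 `CN(C)CC[C@H](CSc1ccccc1)Nc1ccc(S(=O)(=O)NC(=O)c2ccc(N3CCC(=Cc4cccnc4)CC3)cc2)cc1[N+](=O)[O-]` differs from compound 2 in one place: pyridin-3-yl in place of 4-fluorophenyl on a double-bonded chain carbon bound to a double-bonded ring carbon. For the measured compounds named here, no measured pair shows this kind of swap, so the expectation rests on compound 2 alone. The step from compound 2 to compound 3 is expected to be small, a 1.8-fold higher number from compound 2 to compound 3 (0.25 log units; within the scatter), not beyond the scatter, and if anything toward a weaker number. Compound 3 is therefore estimated at 6 nM, with a range from 2 nM to 20 nM.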

Compound 3, inhibition constant: 68 nM
The estimate for compound 3 lay 11-fold (1.05 log units) below the measured number, outside the stated range (above it).
By their numbers in this assay, from the lowest: compound 2; then compound 1; then compound 3.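

In this assay, this position proves sensitive to a single swap: pyridin-3-yl in place of 4-fluorophenyl, on a double-bonded chain carbon bound to a double-bonded ring carbon, gives a 20-fold higher number from compound 2 to compound 3 (1.30 log units; beyond the scatter). The entering ring carries a nitrogen and a hydrogen-bond acceptor, while the leaving ring carries a fluorine, and this one pair cannot separate those differences. Nothing shown here accounts for the size of this step.

As far as these compounds go, whether a plain phenyl or a pyridin-4-yl group at this place would stay close to compound 2 or fall toward compound 3 remains open.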